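The source may report more compounds than this note shows. Statements on the series, on what has been measured and on what is new or still open speak of the compounds shown alone.

In a functional assay on QGY7701 cells (Homo sapiens) for cytotoxicity, read by MTT assay, with a stated time of 24 h (on this read-out higher numbers stand for weaker inhibition and lower numbers for stronger inhibition), compound 1 `C=CC1=C(C(=O)NCc2ccccc2F)C(c2ccc(F)cc2)OC1` gives 51400 nM. Compound 2 `C=CC1=C(C(=O)NCCCCC)C(c2ccc(OC)cc2)OC1` returns no number in this assay, only a limit of > 100000 nM. This is the limit of > 100000 nM in this assay, at which 1 of the 2 values shown sits. Compound 3 `C=CC1=C(C(=O)NCc2ccccc2F)C(c2ccc(OC)cc2)OC1` differs from compound 2 by 2-fluorophenyl in place of butyl on a saturated chain carbon bound to an amide-type nitrogen, the same amide substituent that compound 1 carries. Within the data shown here, no step between two measured compounds is available here. Compound 1, bearing that substituent, gives 51400 nM in this assay. On that basis a step of an at least 1.6-fold lower number from compound 2 to compound 3 (0.22 log units; that floor lies within the scatter) toward stronger inhibition is expected. Compound 3 is estimated at 60000 nM in this assay, with a range from 20000 nM to 150000 nM.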

Compound 3, half-maximal inhibitory concentration: > 100000 nM
Compound 3: a limit, no number; the forecaster's own chance of this, stated with the estimate: 35%; middle value at least 1.6-fold (0.22 log units) from the limit.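

In this assay compound 3 gives only a limit, as compound 2 does: the limit of > 100000 nM in this assay, at which 2 of the 3 values shown sit.
The step between these two cannot be read, so 2-fluorobenzyl in place of pentyl shows no readable effect while methoxy is present. With the amide substituent held, methoxy in place of fluoro on an aromatic carbon gives an at least 1.9-fold higher number from compound 1 to compound 3 (0.28 log units; that floor lies within the scatter) and so offers the first readable step, pointing toward weaker inhibition. Still open, on these data alone, is whether that step would also hold with the pentyl amide, and whether an amine or a carboxylic acid on that aromatic carbon would give a number rather than a limit.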